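The source may hold more compounds than are shown below. What is called first, only, known or untested is meant among the compounds shown, and "the series" means these compounds.

Measured compounds:
Compound 1 `COc1ccc(C2CC(=NO)CC(c3ccc(OC)cc3)N2C)cc1`: in a functional assay, with a stated time of 30 min (on this read-out higher numbers stand for weaker inhibition and lower numbers for stronger inhibition), compound 1 gives 380000 nM.
Compound 2 `COc1ccc(C2CC(=NOC(=O)c3ccc(F)cc3)CC(c3ccc(OC)cc3)N2C)cc1`: in this assay compound 2 gives 152000 nM.
Compound 3 `COc1ccc(C2CC(=NOC(=O)c3cc(O)cc(O)c3)CC(c3ccc(OC)cc3)N2C)cc1`: in this assay compound 3 gives 19000 nM.

Compound 3 holds the lowest number of the three, and both of its steps to the others lie beyond the scatter: a 20-fold lower number from compound 1 to compound 3 (1.30 log units; beyond the scatter) and an 8.0-fold lower number from compound 2 to compound 3 (0.90 log units; beyond the scatter). Compound 4 `COc1ccc(C2CC(=NOC(=O)c3cc(O)c(O)c(O)c3)CC(c3ccc(OC)cc3)N2C)cc1` differs from compound 3 in a single place: hydroxy in place of hydrogen on an aromatic carbon. Among the measured compounds shown here, no measured step adds one hydroxy group to a ring that already carries two, so the closest guide is an 8.0-fold lower number from compound 2 to compound 3 (0.90 log units; beyond the scatter), in which a ring bearing two hydroxy groups took the place of one bearing a fluorine, alongside the smaller step of a 2.5-fold lower number from compound 1 to compound 2 (0.40 log units; beyond the scatter). Both show a lower number when this part of the molecule is enlarged or furnished with hydroxy groups. For the measured compounds named here, in compound 4 the new group enters a ring that already holds two hydroxy groups, so the expected step is smaller than the one from compound 2 to compound 3, yet still downward and beyond the scatter. In this assay compound 4 is therefore expected to show a 2.4-fold lower number from compound 3 to compound 4 (0.38 log units; beyond the scatter). The estimated value for compound 4 is 8000 nM, with a range from 3000 nM to 25000 nM.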

Compound 4, half-maximal inhibitory concentration: 18000 nM
The estimate for compound 4 lay 2.3-fold (0.35 log units) below the measured number; low and high end bracket the measured number.
By their numbers in this assay, from the lowest: compounds 4 and 3 (each within the scatter of the next); then compound 2; then compound 1.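

In this assay the aromatic carbon ortho to two hydroxy groups and para to a large group takes one more hydroxy group with no shift that stands out from the scatter (a 1.1-fold lower number from compound 3 to compound 4 (0.02 log units; within the scatter)). The earlier compounds shown here each gave a lower number when this end of the molecule changed, and compound 4 goes against that pattern, so adding hydroxy groups does not keep lowering the number; the distance from the less elaborate compounds stays much the same as it was for the 3,5-dihydroxyphenyl ring (an 8.4-fold lower number from compound 2 to compound 4 (0.93 log units; beyond the scatter); a 21-fold lower number from compound 1 to compound 4 (1.32 log units; beyond the scatter)). Nothing available here offers an explanation for this flat result.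

It remains open whether the hydroxy groups at the other two ring positions each contribute, since a ring with just one hydroxy group is not among the compounds shown. From the compounds shown here alone, it is also open whether a methoxy group or an amine at the carbon para to the large group would lower the number or leave it where it is.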